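Replacing a dichlorophenyl sulfonamide with a methyl sulfonamide

The source may report more compounds than this note shows. Statements on the series, on what has been measured and on what is new or still open speak of the compounds shown alone.

Measured compounds:
compound 1, `O=S(=O)(Nc1ccc2oc(-c3ccccc3)nc2c1)c1cccc(Cl)c1`, > 100000 nM (a limit of the assay)
compound 2, `COc1ccc(Cl)cc1S(=O)(=O)Nc1ccc2oc(-c3ccccc3)nc2c1`, > 100000 nM (a limit of the assay)
compound 3, `O=S(=O)(Nc1ccc2oc(-c3ccccc3)nc2c1)c1ccc(Cl)c(Cl)c1`, > 100000 nM (a limit of the assay)

Three sulfonamides built on a shared core were tested in an assay on cells for inhibition of HSP60/HSP10 (Homo sapiens), with a stated time of 60 min; a higher number here means a weaker inhibitor, a lower number a stronger inhibitor. For compound 3 the result is only a limit, > 100000 nM, and not a number. The same holds for compound 1 and for compound 2. Because of the limit of > 100000 nM in this assay, at which 3 of the 3 values shown sit, none of the steps among them can be read: a step that the two limits leave unreadable from compound 1 to compound 2, a step that the two limits leave unreadable from compound 1 to compound 3 and a step that the two limits leave unreadable from compound 2 to compound 3 all remain of unknown size and direction.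

Compound 4, `CS(=O)(=O)Nc1ccc2oc(-c3ccccc3)nc2c1`, is the next candidate. It differs from compound 3 in one place: methyl in place of 3,4-dichlorophenyl on a sulfonyl sulfur. The measured steps offer no guidance here, since every one of them ends at the assay limit, and none of them exchanges the aromatic ring on the sulfonyl sulfur for a small chain. The most that can be said is that compound 3 shows no measurable inhibition, and the change to compound 4 removes the only variable part that has been explored so far.

The expectation for compound 4 is therefore 150000 nM, within 50000 nM to 500000 nM, corresponding to an estimated step that the limit leaves unreadable from compound 3 to compound 4, with a strong chance that this assay again reports only a limit.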

Compound 4, half-maximal inhibitory concentration: > 100000 nM
Compound 4 ended at the assay's limit; the forecaster's own chance of this, stated with the estimate: 85%; the middle value lies beyond the limit too.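

Compound 4 gives only a limit and not a number, so the steps to it from compound 1, compound 2 and compound 3 cannot be read, because all four results stop at the same point: the limit of > 100000 nM in this assay, at which 4 of the 4 values shown sit.

The compounds shown leave open whether any group on the sulfonyl sulfur of the shared core gives measurable inhibition in this assay.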